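The source may hold more compounds than are shown below. What is called first, only, known or untested is meant among the compounds shown, and "the series" means these compounds.

Compound 1 `CC(C)Oc1ccc(-c2nnc(-c3ccnn3C)s2)cc1Cl` is the reference point of this account. In a physicochemical assay for lipophilicity, at pH 7.4 (a lower number here means a more polar compound, a higher number a more lipophilic compound), compound 1 gives 7.04, the highest of the three numbers available. The other two measured compounds sit well away from it: compound 3 `Cc1nn(-c2nnc(-c3ccc(OC(C)C)c(Cl)c3)s2)c(C)c1CCC(=O)O` gives 4.3 in this assay, a number beyond the scatter below compound 1, and compound 2 `CC(C)Oc1ccc(-c2nnc(-n3cc4c(n3)CCN(CCCC(=O)O)C4)s2)cc1Cl` gives 3.56 in this assay, further still. Neither of these two differs from compound 1 in one place only, so their numbers show only how far apart the measured compounds lie, not what any single change does.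

The unmeasured compound 4 `CC(C)Oc1ccc(-c2nnc(-c3cncn3C)s2)cc1Cl` differs from compound 1 in one place: 1-methyl-1H-imidazol-5-yl in place of 1-methyl-1H-pyrazol-5-yl on an aromatic carbon. The two have the same atoms, joined differently, and the group that enters carries the same count of hydrogen-bond donors and acceptors as the one that leaves. Going by the values given here, no measured pair here shows a step of this kind, so the size of the step must be expected rather than read off. A modest downward step from compound 1 to compound 4 is expected, a number 0.64 log units lower from compound 1 to compound 4 (beyond the scatter), somewhat beyond the scatter. In this assay compound 4 is therefore estimated at 6.4, within a range from 5.7 to 7.1.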

Compound 4, distribution coefficient: 5.7
Compound 4: the middle estimate sits 0.70 log units above what was measured, and the stated range covers the measured number.
By their numbers in this assay, from the lowest: compound 2; then compound 3; then compound 4; then compound 1.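

In this assay, going by these compounds alone, 1-methyl-1H-imidazol-5-yl in place of 1-methyl-1H-pyrazol-5-yl on an aromatic carbon gives a number 1.34 log units lower from compound 1 to compound 4 (beyond the scatter), the first step in this account that can be read as a single change, and a large one. The two groups have the same atoms, joined differently, and the same counts of hydrogen-bond donors and acceptors, so at this position a large step arises with nothing added to the compound and nothing taken away. Nothing given here bears on why the step has this size.

This single step cannot say whether another five-membered aromatic ring with 2 hetero atoms, placed on the same aromatic carbon, would move the number as far, or whether the step depends on the rest of the shared core. It also leaves open how far the number would move if an amine or a longer chain were carried on the 1-methyl-1H-imidazol-5-yl group of compound 4, and whether the same group would give a step of similar size in a compound with a different substituent.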